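The compounds below may be only part of what the source reports. "The series", "measured", "known", "first", "only" and "open" are said of these compounds alone.

Compound 2 `O=c1nc(-c2ccccc2)c2cc(-c3ccccc3)ccc2[nH]1` was tested in an ADME assay on THP-1 cells (Homo sapiens) for cytotoxicity, read by MTT assay, with a stated time of 72 h; on this read-out lower numbers stand for an effect already at smaller amounts and higher numbers for an effect only at larger amounts of compound. In this assay compound 2 gives only a limit of the measurement, > 50000 nM, and not a number. Compound 1 `O=c1nc(-c2ccccc2)c2cc(-c3ccc(N4CCCC4)nc3)ccc2[nH]1` likewise gives only a limit in this assay, > 50000 nM. Both readings sit at the limit of > 50000 nM in this assay, at which 2 of the 2 values shown sit, which leaves the two compounds indistinguishable on this read-out. Compound 3 `CN1CCN(c2ccc3[nH]c(=O)nc(-c4ccccc4)c3c2)CC1` has not yet been measured. It differs from compound 2 by a single change, (4-methylpiperazin-1-yl in place of phenyl on an aromatic carbon), in which the phenyl leaves and a 4-methylpiperazin-1-yl enters on the shared core. Among the measured compounds shown here, since both known values rest at the limit, there is no measured step to build on, and the expected step of a number no higher from compound 2 to compound 3 (the limit leaves the size open) is taken as none beyond the usual scatter. Compound 3 is therefore estimated to show 50000 nM in this assay, within a range from 15000 nM to 150000 nM, with a strong chance that once more only a limit is recorded.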

Compound 3, half-maximal effective concentration: > 50000 nM
Compound 3 was reported as a limit (the forecaster's own chance of this, stated with the estimate: 80%); the middle value lies on the limit itself.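

No step can be read between compound 2 and compound 3, as both readings in this assay are limits and not numbers: the limit of > 50000 nM in this assay, at which 3 of the 3 values shown sit. The compounds shown leave open what amount of any of them would produce an effect, and whether 4-methylpiperazin-1-yl in place of phenyl changes that amount at all.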